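A few compounds are considered here, and "the series" means these few. Any claim that something is new, unique, unknown or untested is made for them only; others in the source may bear on it.

Measured so far in an ADME assay on HEL cells (Homo sapiens) for cytotoxicity, with a stated time of 3 days; a higher number here means that more compound is tolerated, a lower number that less compound is tolerated:
compound 1, `CCC1(Cc2ccccc2)OS(=O)(=O)C=C1OCc1ccc(C)cc1`: 41500 nM
compound 2, `CCC1(Cc2ccccc2)OS(=O)(=O)C=C1OCc1ccc(Cl)cc1`: a limit of the assay, > 200000 nM
compound 3, `CCC1(Cc2ccccc2)OS(=O)(=O)C=C1OCCCc1ccccc1`: 133000 nM

Compound 3 stands highest of the two numbers given; the nearest number is that of compound 1, with a 3.2-fold higher number from compound 1 to compound 3 (0.51 log units; beyond the scatter). Compound 2 gives only a limit (the limit of > 200000 nM in this assay, at which 1 of the 3 values shown sits), and an at least 1.5-fold lower number from compound 2 to compound 3 (0.17 log units; that floor lies within the scatter).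

Compound 4, `CCC1(Cc2ccccc2)OS(=O)(=O)C=C1OCc1ccc(F)cc1`, has not been measured. It differs from compound 3 in one place: 4-fluorophenyl in place of phenethyl on a saturated chain carbon bound to an oxygen on an unsaturated carbon.

Among the compounds with values here, two measured steps bear on this change. The step from a 4-methylphenyl to phenethyl gave a 3.2-fold higher number from compound 1 to compound 3 (0.51 log units; beyond the scatter); read backwards, an aryl in place of phenethyl would lower the number by about that much. The step from a 4-chlorophenyl to phenethyl gave an at least 1.5-fold lower number from compound 2 to compound 3 (0.17 log units; that floor lies within the scatter); read backwards, the number might rise. Compound 4 carries fluoro where compound 2 carries chloro and compound 1 carries methyl, so the two directions pull against each other, and the expected step is a 1.5-fold lower number from compound 3 to compound 4 (0.17 log units; within the scatter), which may not exceed the scatter. The estimate for compound 4 is 90000 nM, expected between 30000 nM and 250000 nM.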

Compound 4, half-maximal cytotoxic concentration: > 50000 nM
Compound 4: a limit, no number; the forecaster's own chance of this, stated with the estimate: 25%; the middle value is on the limit's open side.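

In this assay compound 4 gives only a limit of the assay, not a number: the limit of > 50000 nM in this assay, at which 1 of the 4 values shown sits.

The steps to compound 4 from compound 3 and from compound 2 cannot be read, so 4-fluorophenyl in place of phenethyl has no measured size. The one readable step is an at least 1.2-fold higher number from compound 1 to compound 4 (0.08 log units; that floor lies within the scatter), so the change from methyl to fluoro is not shown to go beyond the scatter, whereas chloro in place of methyl gave an at least 4.8-fold higher number from compound 1 to compound 2 (0.68 log units; beyond the scatter).

Still open, going by these compounds, is where compound 4 stands against compound 2 and compound 3, and whether fluoro differs from chloro on this aromatic carbon at all. Also open, on these data alone, is how an amine or a methoxy in place of fluoro on that carbon, or a chain longer than phenethyl, would read in this assay.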